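Extending a methoxy to benzyloxy on a receptor binder

This account rests on a few compounds, and the source may have more. Where it says the series, first, only, none or still open, it means among the compounds named here.

Of the compounds shown here, two have been tested in an assay on CHO cells for displacement of a labelled ligand from Free fatty acid receptor 1 (Homo sapiens), read by scintillation counting, with a stated time of 90 min, in the presence of a further agent that is not named here; on this read-out higher numbers stand for weaker inhibition and lower numbers for stronger inhibition. Compound 1 `Cc1cccc(C)c1-c1cccc(COc2ccc3c(c2)CC3CC(=O)O)c1` gives 1200 nM. Compound 2 `COc1ccc(COc2ccc3c(c2)OCC3CC(=O)O)cc1-c1c(C)cccc1C` gives 130 nM, the lower of the two numbers, and the gap between them is wider than the usual scatter; the two structures differ in several places, so the gap cannot be tied to any single change.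

Compound 3 `Cc1cccc(C)c1-c1cc(COc2ccc3c(c2)OCC3CC(=O)O)ccc1OCc1ccccc1` has not yet been measured. It differs from compound 2 in one place: phenyl in place of hydrogen on a saturated chain carbon bound to an oxygen on an aromatic ring. Among the compounds with values here, no pair of measured compounds shows this change, so there is no direct guide to its effect.

Within the data shown here, with no measured precedent, the expected step from compound 2 to compound 3 is small, a 1.5-fold higher number from compound 2 to compound 3 (0.19 log units; within the scatter), and may well fall within the scatter. On that basis compound 3 is estimated at 200 nM, in a range from 40 nM to 1000 nM.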

Compound 3, inhibition constant in the Free fatty acid receptor 1 assay: 6.9 nM
For compound 3 the middle estimate is 29-fold (1.46 log units) above the measured one, outside the stated range (below it).
By their numbers in the Free fatty acid receptor 1 assay, from the lowest: compound 3; then compound 2; then compound 1.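

In the Free fatty acid receptor 1 assay, going from methoxy to benzyloxy gives a 19-fold lower number from compound 2 to compound 3 (1.28 log units; beyond the scatter), so this position accepts a much larger group, and the added phenyl comes with a clear gain in binding. The earlier compounds shown here could not show this, since compound 1 and compound 2 differ in several places and no single change could be read from them. In a physicochemical assay for lipophilicity, measured as octanol-water partition, at pH 7.4 (a higher number here means a more lipophilic compound, a lower number a more polar compound), compound 2 gives 3.31 and compound 3 gives 4.53. The gain comes with a rise in the physicochemical assay, which may account for part of it, though this single pair cannot separate the two effects: the measured distribution coefficient of compound 2, 3.31, and of compound 3, 4.53, a number 1.22 log units higher (beyond the scatter)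

As far as these compounds go, whether the gain needs the phenyl ring itself remains open. A cyclohexyl ring or a pyridine ring in the same place, or a longer chain carrying the phenyl, would help to answer that, and would show how far this position can be extended.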